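The compounds below may be only part of what the source reports. "The series", "measured", "known", "first", "only" and "open" are said of these compounds alone.

Measured so far:
Compound 1 `O=C(Nc1cccc(OC(F)(F)F)c1)c1cc(=O)[nH]c2cc(Br)ccc12`: > 20000 nM (a limit)
Compound 2 `O=C(Nc1cccc(F)c1)c1cc(=O)[nH]c2cc(F)ccc12`: > 20000 nM (a limit)
Compound 3 `O=C(Nc1cc(F)cc(F)c1)c1cc(=O)[nH]c2cc(F)ccc12`: > 20000 nM (a limit)

In a functional assay on KYSE-70 cells for antiproliferative activity against KYSE-70 cell line (Homo sapiens), read by MTT assay, with a stated time of 72 h (on this read-out lower numbers stand for stronger inhibition and higher numbers for weaker inhibition), compound 3 gives > 20000 nM, which is a limit of the assay and not a number. It therefore has no exact place in the series, and the same holds for the other two compounds: the limit of > 20000 nM in this assay, at which 3 of the 3 values shown sit.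

Compound 4 `COc1ccc2c(C(=O)Nc3cc(F)cc(F)c3)cc(=O)[nH]c2c1` keeps everything in compound 3 except one group, with methoxy in place of fluoro on an aromatic carbon of the shared core (methoxy in place of fluoro on an aromatic carbon).

For the measured compounds named here, no measured step covers this swap. Going by the values given here, the only step available is a step that the two limits leave unreadable from compound 2 to compound 3, a different change, fluoro in place of hydrogen, and its size cannot be read. Among the compounds with values here, the firmest guide is therefore the flat picture in the limit of > 20000 nM in this assay, at which 3 of the 3 values shown sit, where no compound gives a readable number despite the different groups on compounds 1, 2 and 3. A clear gain in this assay is not expected, and compound 4 will most likely report only a limit again.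

The estimate implies an expected a number no higher from compound 3 to compound 4 (the limit leaves the size open), which is no firm change. For compound 4 the estimated value is 20000 nM, with an expected range from 7000 nM to 40000 nM.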

Compound 4, half-maximal inhibitory concentration: > 20000 nM
Compound 4 gave a limit, no number; the forecaster's own chance of this, stated with the estimate: 75%; the middle value lies on the limit itself.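

Compound 3 and compound 4 both give only a limit in this assay, so the swap of methoxy in place of fluoro between them cannot be read as a step of any size. The compounds shown leave open which change, if any, would give a readable number, as the picture remains flat: the limit of > 20000 nM in this assay, at which 4 of the 4 values shown sit.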